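The compounds below may be only part of what the source reports. "The series", "measured", "known", "first", "only" and "open" are said of these compounds alone.

Measured compounds:
compound 1 `CC(C)c1cccc(C(C)C)c1NC(=O)NS(=O)(=O)N(C)C` gives 3900 nM in an assay on liver for inhibition of sterol O-acyltransferase 1 (Rattus norvegicus), using microsomes; on this read-out lower numbers stand for stronger inhibition and higher numbers for weaker inhibition;
compound 2 `CC(C)NS(=O)(=O)NC(=O)Nc1c(C(C)C)cccc1C(C)C` gives 18000 nM in this assay.

Among these two numbers compound 2 stands highest; the only other compound is compound 1, and the gap between them is given by a 4.6-fold higher number from compound 1 to compound 2 (0.66 log units; beyond the scatter), a modest step that lies beyond the scatter. Compound 3 `CCN(CC)S(=O)(=O)NC(=O)Nc1c(C(C)C)cccc1C(C)C` has not yet been measured in this assay. It differs from compound 2 in one place: diethylamino in place of isopropylamino on a sulfonyl sulfur. Going by the values given here, the single measured step that bears on this change is a 4.6-fold higher number from compound 1 to compound 2 (0.66 log units; beyond the scatter), where a dimethylamino on the sulfonyl sulfur, without a hydrogen-bond donor, gave the lower number and the isopropylamino the higher one. Since diethylamino again carries no hydrogen-bond donor, compound 3 is expected to move back toward compound 1, with a 3.0-fold lower number from compound 2 to compound 3 (0.48 log units; beyond the scatter) as the estimated step. Compound 3 is therefore estimated at 6000 nM, within a range from 2000 nM to 20000 nM.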

Compound 3, half-maximal inhibitory concentration: 2500 nM
For compound 3 the middle estimate is 2.4-fold (0.38 log units) above the measured one; the measured number falls inside the stated range.
By their numbers in this assay, from the lowest: compounds 3 and 1 (each within the scatter of the next); then compound 2.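

In this assay the change on the sulfonyl sulfur from isopropylamino to diethylamino gives a 7.2-fold lower number from compound 2 to compound 3 (0.86 log units; beyond the scatter) and shows that the higher number of compound 2 is not simply a matter of a larger group at this place. Going from dimethylamino to diethylamino gives a 1.6-fold lower number from compound 1 to compound 3 (0.19 log units; within the scatter) and so lies within the scatter, which leaves isopropylamino, the only one of the three groups with a hydrogen-bond donor, standing apart from the other two. Nothing measured here accounts for this difference.

The compounds shown do not separate the donor from the branching of isopropylamino as the feature that goes with the higher number. As far as these compounds go, how ethylamino, or a longer chain such as dibutylamino, would read out on this sulfur stays open.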